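The source may report more compounds than this note shows. Statements on the series, on what has been measured and on what is new or still open speak of the compounds shown alone.

Measured so far:
compound 1, `COC(C)(C)CCCC(C)C/C=C/C(C)=C/C(=O)OCCC(C)C`: 7.03
compound 2, `CCNC(=O)OC(C)(C)CCCC(C)C/C=C/C(C)=C/C(=O)OCC`: 5.65
compound 3, `CC(/C=C/CC(C)CCCC(C)C)=C\C(=O)NC(C)C`: 5.65

Three members of the series have a number in a physicochemical assay for lipophilicity; a higher number here means a more lipophilic compound, a lower number a more polar compound. Compound 1 holds the highest of the three; compound 2 and compound 3 sit at the same number, which lies beyond the scatter from compound 1. For the measured compounds named here, no pair among the measured compounds differs in one place only, so no single step within the measured set can be read off.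

The next compound, compound 4, `CCC(C)C(=O)/C=C(C)/C=C/CC(C)CCCC(C)(C)OC`, still lacks a number in this assay. Against compound 1 the change is sec-butyl in place of isopentyloxy on a carbonyl carbon. Read one bond further out, isopentyloxycarbonyl becomes (sec-butyl)carbonyl.

Expected for this change: a step from compound 1 downward, a number 0.93 log units lower from compound 1 to compound 4 (beyond the scatter), beyond the scatter, since the group that enters carries fewer heavy atoms than the one that leaves. On that basis compound 4 is estimated at 6.1, with a range of 5.5 to 6.7.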

Compound 4, partition coefficient: 6.02
Beside the measured number, compound 4's estimate is 0.08 log units above it, and the stated range covers the measured number.
By their numbers in this assay, from the lowest: compounds 2 and 3 (each within the scatter of the next); then compound 4; then compound 1.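

For the compounds shown here, this is the first step that can be read at a single place: in this assay, sec-butyl in place of isopentyloxy on a carbonyl carbon gives a number 1.01 log units lower from compound 1 to compound 4 (beyond the scatter). The number at this position therefore moves with the group on the carbonyl carbon while the rest of compound 1 stays the same. The exchange alters two counts at once, with the heavy atoms falling from 6 to 4 and the hydrogen-bond acceptors from 1 to 0, and no measurement shown gives a reason for the step.

A single step cannot separate the loss of the oxygen from the loss of heavy atoms; an n-pentyl or isopentyl group on the same carbonyl carbon would bear on that. As far as these compounds go, how an amine, a carboxylic acid or a longer chain at this place would compare remains open.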